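Fluoro in place of hydrogen on the benzamido group

The source may report more compounds than this note shows. Statements on the series, on what has been measured and on what is new or still open speak of the compounds shown alone.

Compound 1 `COc1cccc(-c2nn(-c3ccccc3)cc2-c2ccnc(NCCNC(=O)Nc3cccc(C(F)(F)F)c3)c2)c1`: 1910 nM
Compound 2 `COc1cccc(-c2nn(-c3ccccc3)cc2-c2ccnc(NCCCNC(=O)Nc3ccc(Cl)c(Cl)c3)c2)c1`: 1890 nM
Compound 3 `O=C(NCCCNc1cc(-c2cn(-c3ccccc3)nc2-c2cccc(O)c2)ccn1)c1ccccc1`: 2300 nM

These three values come from a functional assay on cells (Panel melanoma (Carcinoma cell lines), Homo sapiens) for antiproliferative activity; a higher number here means a weaker inhibitor of growth, a lower number a stronger inhibitor of growth. Compound 3 carries the highest number of the three, but its gaps to compound 1 and to compound 2 both lie within the scatter, so the three cannot be ranked against one another in this assay. Compound 4 `O=C(NCCCNc1cc(-c2cn(-c3ccccc3)nc2-c2cccc(O)c2)ccn1)c1ccc(F)cc1` differs from compound 3 by fluoro in place of hydrogen on an aromatic carbon. Among the compounds with values here, no measured pair shows this change, so nothing in the data points to a step beyond the scatter in either direction. Compound 4 is therefore expected to give about 2200 nM, within 1000 nM to 4800 nM. The expected step is a 1.0-fold lower number from compound 3 to compound 4 (0.02 log units; within the scatter).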

Compound 4, concentration for 50% growth inhibition: 1910 nM
Estimate against measurement, compound 4: 1.2-fold (0.06 log units) above; measured number inside the range.
By their numbers in this assay, from the lowest: compounds 2, 1, 4 and 3 (each within the scatter of the next).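

Within the data shown here, compounds 3 and 4 form the first pair in this set that differs in one place. In this assay, phenyl to 4-fluorophenyl gives a 1.2-fold lower number from compound 3 to compound 4 (0.08 log units; within the scatter), so this aromatic carbon accepts fluoro without a step beyond the scatter. Nothing available explains this result.

On these data alone, whether an amine, a carboxylic acid or a chlorine at this carbon would give a step beyond the scatter remains open. So does the effect of a longer chain in the linker of compound 4.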